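Swapping the Chlorobenzyl Ether for a Benzoyl Ester

A few compounds are considered here, and "the series" means these few. Any claim that something is new, unique, unknown or untested is made for them only; others in the source may bear on it.

Compound 2 `CCC1(Cc2ccccc2)OS(=O)(=O)C=C1OCc1ccccc1Cl` gives 38000 nM in an ADME assay on HEL cells (Homo sapiens) for cytotoxicity, with a stated time of 3 days (on this read-out lower numbers stand for higher toxicity in this test and higher numbers for lower toxicity in this test), the lowest of the two numbers shown. Compound 3 `CCC1(Cc2ccccc2)OS(=O)(=O)C=C1OCCCc1ccccc1` gives 133000 nM in this assay. For compound 1 `CCC1(Cc2ccccc2)OS(=O)(=O)C=C1OCc1ccc(OC)cc1` the read-out in this assay is a limit of the test rather than a number, > 200000 nM, matching (the limit of > 200000 nM in this assay, at which 1 of the 3 values shown sits). Compound 4 `CCC1(Cc2ccccc2)OS(=O)(=O)C=C1OC(=O)c1ccccc1` is not yet measured; it differs from compound 2 by benzoyl in place of 2-chlorobenzyl on an oxygen on an unsaturated carbon. Two measured steps change the same side group: an at least 5.2-fold lower number from compound 1 to compound 2 (0.72 log units; beyond the scatter) and a 3.5-fold higher number from compound 2 to compound 3 (0.54 log units; beyond the scatter). In both, the 2-chlorobenzyl group goes with the lowest number, so compound 4 is expected to give a modestly higher number, a 2.6-fold higher number from compound 2 to compound 4 (0.42 log units; beyond the scatter). Compound 4 is accordingly estimated at 100000 nM, within the range 30000 nM to 300000 nM.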

Compound 4, half-maximal cytotoxic concentration: > 200000 nM
Compound 4 was reported as a limit; the forecaster's own chance of this, stated with the estimate: 25%; middle value at least 2.0-fold (0.30 log units) from the limit.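

Replacing 2-chlorobenzyl with benzoyl on this oxygen gives an at least 5.2-fold higher number from compound 2 to compound 4 (0.72 log units; beyond the scatter) in this assay, so the number rises with an ester here, whereas compounds 1, 2 and 3 all carry ethers. Compound 4 gives > 200000 nM, which is a limit of the test and not a number. Compound 4 therefore cannot be ranked against compound 1, as both stop at the same limit: the limit of > 200000 nM in this assay, at which 2 of the 4 values shown sit.

Still open, from the compounds shown here alone, is whether the low number of compound 2 goes with its chlorine or with its ether link. A 2-chlorobenzoyl group at this oxygen would separate the two.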